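The source may report more compounds than this note shows. Statements on the series, on what has been measured and on what is new or still open speak of the compounds shown alone.

Measured compounds:
compound 1 `CCCCCCCCCCCCNC(=O)[C@@H](NC(=O)c1cccs1)[C@@H](C)O` — 30100 nM
compound 2 `CCCCCCCCCCCCCCNC(=O)[C@@H](NC(=O)c1ccco1)[C@@H](C)O` — > 400000 nM

In a functional assay on HepG2 cells (Homo sapiens) for cytotoxicity, read by MTT assay, with a stated time of 48 h (a lower number here means a stronger inhibitor, a higher number a weaker inhibitor), compound 1 gives 30100 nM. Compound 2 gives only a limit of the assay, > 400000 nM. The two compounds differ in more than one place, so their values are reported side by side without a measured step between them; together they show compound 1 with a number and compound 2 at the limit, as the evidence notes (the limit of > 400000 nM in this assay, at which 1 of the 2 values shown sits).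

Compound 3 `CCCCCCCCCCCCCCNC(=O)[C@@H](NC(=O)c1cccs1)[C@@H](C)O` is not yet measured. It differs from compound 2 in one place: thiophen-2-yl in place of furan-2-yl on a carbonyl carbon. Within the data shown here, no measured pair shows this change alone, so the size of the step in this assay is uncertain, though a step toward a stronger inhibitor is expected because compound 1, which also carries the thiophen-2-yl group, gives 30100 nM. The step from compound 2 to compound 3 is expected to be an at least 4.0-fold lower number from compound 2 to compound 3 (0.60 log units; beyond the scatter). Compound 3 is therefore estimated at 100000 nM, within a range of 25000 nM to 400000 nM.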

Compound 3, half-maximal inhibitory concentration: 88400 nM
Estimate against measurement, compound 3: 1.1-fold (0.05 log units) above; the range from low to high includes it.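

In this assay, thiophen-2-yl in place of furan-2-yl on a carbonyl carbon now has a measured minimum size: an at least 4.5-fold lower number from compound 2 to compound 3 (0.65 log units; beyond the scatter). As far as these compounds go, its full size remains unknown, since compound 2 gives only a limit: the limit of > 400000 nM in this assay, at which 1 of the 3 values shown sits. Ethyl in place of hydrogen on a saturated chain carbon also moves the number, with a 2.9-fold higher number from compound 1 to compound 3 (0.47 log units; beyond the scatter). The compounds shown leave open how furan-2-yl behaves with the chain of compound 1. They also leave open whether phenyl on the carbonyl carbon, or a longer chain, would shift the number further.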